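Extending the aminobenzyl group of compound 1

The source may hold more compounds than are shown below. What is called first, only, known or untested is meant among the compounds shown, and "the series" means these compounds.

Measured compounds:
- compound 1, `Nc1cccc(CNc2cc(Br)cc3[nH]ncc23)c1`, in this assay: "not active" (no number reported)
- compound 2, `NS(=O)(=O)c1ccc(CNc2cc(Br)cc3[nH]ncc23)cc1`, in this assay: 75%

Two compounds share a core and differ in the group hanging from the benzyl ring. In an assay for inhibition of Tryptophan 2,3-dioxygenase (Homo sapiens), with a stated time of 1 h, tested at 10 uM (a higher number here means more inhibition at the concentration tested (going by the name of the read-out), a lower number less inhibition), compound 1 gives "not active" (no number reported), so no number stands for it; it is simply recorded as showing no inhibition at the test concentration. Compound 2 carries a sulfonamide instead of the amine, and in this assay compound 2 gives 75%. Going by the values given here, no step between these two is computed here, so only the two readings themselves can be compared.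

Compound 3, `OC1CCCC(Nc2cccc(CNc3cc(Br)cc4[nH]ncc34)c2)C1`, has not yet been tested. It differs from compound 1 in one place: 3-hydroxycyclohexyl in place of hydrogen on a nitrogen on an aromatic ring. The amine of compound 1 thus becomes a (3-hydroxycyclohexyl)amino group. Since compound 1 gives no number, the size of the step cannot be set against a baseline; a moderate rise in inhibition in this assay is expected, but it may also stay within the scatter. For compound 3 the expected inhibition in this assay is 30%, with a range from 0% to 65%.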

Compound 3, a percentage reported as inhibition, at one concentration (the size of the read-out at that concentration, not a potency): 50%
The estimate for compound 3 lay 20 percentage points below the measured number; the measured number falls inside the stated range.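

Going by these compounds alone, compound 1 has no number, so no step from compound 1 to compound 3 can be read. The compounds shown leave open whether the ring or the hydroxyl of the 3-hydroxycyclohexyl group matters for the reading of compound 3, and no evidence bears on this result.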